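Piperazinyl for trifluoromethyl on the core of compound 1

The compounds below may be only part of what the source reports. "The series", "measured", "known", "first", "only" and "open" are said of these compounds alone.

Compound 1 `O=C(Nc1ccnnc1)c1cc(C(F)(F)F)ccc1OCc1ccccc1` is the reference point. Within the data shown here, in an assay on Sf9 cells for inhibition of Leucine-rich repeat serine/threonine-protein kinase 2 (Homo sapiens), read by TR-FRET, with stated times of 30 min and 2 h (a lower number here means a stronger inhibitor, a higher number a weaker inhibitor), compound 1 gives 15.9 nM, the second highest of the three numbers so far. Compound 3 `CN1CCN(c2ccc(OCc3ccccc3)c(C(=O)Nc3ccnnc3)c2)CC1` is nearest: in this assay compound 3 gives 12.6 nM, and the step of a 1.3-fold lower number from compound 1 to compound 3 (0.10 log units; within the scatter) is within the scatter. Among the measured compounds shown here, compound 2 `O=C(Nc1cccc(F)c1)c1cc(C(F)(F)F)ccc1OCc1ccc(F)cc1` is furthest, giving 31.6 nM in this assay; no single-point step connects it to compound 1, and its value is within the scatter of that of compound 1.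

Compound 4 `O=C(Nc1ccnnc1)c1cc(N2CCNCC2)ccc1OCc1ccccc1` differs from compound 1 as follows: piperazin-1-yl in place of trifluoromethyl on an aromatic carbon

For the measured compounds named here, the one measured step that bears on this change is a 1.3-fold lower number from compound 1 to compound 3 (0.10 log units; within the scatter), where a 4-methylpiperazin-1-yl replaced the same trifluoromethyl and the number hardly moved. Compound 4 carries a piperazin-1-yl at that same carbon, so a step of similar size is expected; a 1.2-fold lower number from compound 1 to compound 4 (0.09 log units; within the scatter) is the expected outcome, with no movement beyond the scatter. Compound 4 is therefore estimated at 13 nM in this assay, with a range from 5 nM to 35 nM.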

Compound 4, half-maximal inhibitory concentration: 15.9 nM
For compound 4 the middle estimate is 1.2-fold (0.09 log units) below the measured one, within the range that was stated.
By their numbers in this assay, from the lowest: compounds 3, 1, 4 and 2 (each within the scatter of the next, the first and the last beyond it).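

In this assay the step shows no change at the digits printed from compound 1 to compound 4 (within the scatter) for the exchange of trifluoromethyl for piperazin-1-yl, so this carbon, para to the benzyloxy group, also takes a six-membered non-aromatic ring with 1 hydrogen-bond donor. Among these compounds, the step of a 1.3-fold higher number from compound 3 to compound 4 (0.10 log units; within the scatter) adds a comparison the earlier compounds could not give: the ring amine nitrogen reads alike with hydrogen or methyl on it. Compounds 1, 3 and 4 therefore stand within the scatter of one another, with trifluoromethyl, 4-methylpiperazin-1-yl and piperazin-1-yl at this one carbon.

From the compounds shown here alone, it remains open whether a carboxylic acid, an open-chain amine or an acyl group on the ring nitrogen would fit the same picture. Nothing measured here accounts for these close readings.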